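Removing Both Fluorines and Adding a Second Nitrogen

The source may hold more compounds than are shown below. What is called first, only, known or untested is meant among the compounds shown, and "the series" means these compounds.

Three compounds share one core and differ only in the group attached to the amine nitrogen at the end of the four-carbon chain. Compound 1 `Cc1ccc2nc(NCCCCOc3cc(O)c4c(=O)cc(-c5ccccc5)oc4c3)sc2c1` gives 48.4 ug/mL in a functional assay on SK-OV-3 cells (Homo sapiens) for cytotoxicity, read by sulforhodamine B assay, with a stated time of 48 h; a lower number here means a stronger inhibitor, a higher number a weaker inhibitor. Compound 2 `O=c1cc(-c2ccccc2)oc2cc(OCCCCNc3nc4ccc(F)cc4s3)cc(O)c12` gives 33.7 ug/mL in this assay, and compound 3 `O=c1cc(-c2ccccc2)oc2cc(OCCCCNc3nc4c(F)cc(F)cc4s3)cc(O)c12` gives 36.8 ug/mL in this assay. Compound 3 thus holds the second highest of the three numbers: its nearest neighbour is compound 2, with a 1.1-fold higher number from compound 2 to compound 3 (0.04 log units; within the scatter), and its furthest is compound 1, with a 1.3-fold lower number from compound 1 to compound 3 (0.12 log units; within the scatter). Both gaps lie within the scatter, so no order among the three can be claimed.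

Compound 4 `O=c1cc(-c2ccccc2)oc2cc(OCCCCNNc3nc4ccccc4s3)cc(O)c12` is built from compound 3 by the change ((1,3-benzothiazol-2-yl)amino in place of 4,6-difluoro-1,3-benzothiazol-2-yl on an amine nitrogen). The measured steps closest in kind are a 1.1-fold higher number from compound 2 to compound 3 (0.04 log units; within the scatter) and a 1.4-fold lower number from compound 1 to compound 2 (0.16 log units; within the scatter), each swapping one small group on an aromatic carbon and each within the scatter. Going by these compounds, none of them tests the second nitrogen that compound 4 carries, so that part of the change is unexplored. Within the data shown here, the numbers so far point to no step beyond the scatter. Compound 4 is therefore expected to give 38 ug/mL in this assay, between 20 ug/mL and 75 ug/mL. This estimate means a step of a 1.0-fold higher number from compound 3 to compound 4 (0.01 log units; within the scatter).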

Compound 4, half-maximal inhibitory concentration: 51.7 ug/mL
Beside the measured number, compound 4's estimate is 1.4-fold (0.13 log units) below it, and the stated range covers the measured number.
By their numbers in this assay, from the lowest: compounds 2, 3, 1 and 4 (each within the scatter of the next).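

In this assay, the (1,3-benzothiazol-2-yl)amino group gives a 1.4-fold higher number from compound 3 to compound 4 (0.15 log units; within the scatter), and the comparisons with the two other compounds give a 1.5-fold higher number from compound 2 to compound 4 (0.19 log units; within the scatter) and a 1.1-fold higher number from compound 1 to compound 4 (0.03 log units; within the scatter). The earlier steps shown here varied only small groups on an aromatic carbon, whereas this change also places a second nitrogen in the link to the ring system, and even so, all three new steps remain within the scatter. The numbers therefore show no measurable effect of this larger change in this assay, and no measurement is available to explain that result.

Compound 4 differs from the others both in its second nitrogen and in having neither fluorine nor methyl on the ring system, so the contribution of each difference cannot be separated; a plain 1,3-benzothiazol-2-yl group on the amine nitrogen would provide that comparison. Going by these compounds, it also remains open whether a quite different group at this place, such as a carboxylic acid or a morpholine, or a longer chain, would produce a step beyond the scatter.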